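Replacing 2,2,2-trifluoroethoxy in a slowly cleared compound

This account rests on a few compounds, and the source may have more. Where it says the series, first, only, none or still open, it means among the compounds named here.

Compound 1 `O=C(N[C@@H]1CCCC[C@H]1O)c1cnc(OCC(F)(F)F)c(-c2ccc(Cl)cc2)c1`: 0.023 mL/min/kg
Compound 2 `O=C(N[C@@H]1CCCC[C@@H]1O)c1cnc(OCC2CC2)c(-c2ccc(Cl)cc2)c1`: 0.163 mL/min/kg

Both numbers come from an ADME assay (liver) for pharmacokinetics, with Liver microsome (Rattus norvegicus) as the target, read by LC-MS, using microsomes, tested at 2 uM; a higher number here means faster removal of the compound, a lower number slower removal. Compound 1 holds the lower of the two, and compound 2 lies above it by more than the usual scatter. Compound 3 `CN(CC1CC1)c1ncc(C(=O)N[C@@H]2CCCC[C@H]2O)cc1-c1ccc(Cl)cc1` has yet to be read in this assay. It departs from compound 1 in one place: (cyclopropylmethyl)(methyl)amino in place of 2,2,2-trifluoroethoxy on an aromatic carbon. The exchange sits next to the ring nitrogen and ortho to a 4-chlorophenyl group. Within the data shown here, no measured pair isolates this change, so the guide is a loose one. Even so, a three-membered ring of carbon only also occurs in compound 2 at 0.163 mL/min/kg, and the expectation leans towards that number. The expected step is a rise beyond the scatter, estimated as a 6.1-fold higher number from compound 1 to compound 3 (0.78 log units; beyond the scatter). For compound 3 the expected clearance is 0.14 mL/min/kg, with an estimated range of 0.04 mL/min/kg to 0.5 mL/min/kg.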

Compound 3, clearance: 1.73 mL/min/kg
The estimate for compound 3 lay 12-fold (1.09 log units) below the measured number; measured number above the stated range.
By their numbers in this assay, from the lowest: compound 1; then compound 2; then compound 3.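

In this assay, among these compounds, putting (cyclopropylmethyl)(methyl)amino in place of 2,2,2-trifluoroethoxy brings a 75-fold higher number from compound 1 to compound 3 (1.88 log units; beyond the scatter), a large step and the first reading of a change at this position with the rest of compound 1 held fixed. The position is therefore far from indifferent to its substituent, even though the leaving and entering groups match in their counts of heavy atoms, hydrogen-bond donors and hydrogen-bond acceptors, and neither carries a net charge, so those counts do not track the step. What lies behind a step of this size remains unexplained, as no supporting measurement bears on it.

The exchange alters the linking atom, removes the fluorines and adds the three-membered ring all at once, and the compounds shown do not separate these parts. A 2,2,2-trifluoroethylamino group on the same aromatic carbon, with the rest of compound 1 unchanged, would keep the fluorines while changing the link, and so would show how much of the step belongs to each.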